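The compounds below may be only part of what the source reports. "The series", "measured", "known", "first", "only" and "open" are said of these compounds alone.

Measured compounds in an ADME assay on HepG2 cells (Homo sapiens) for cytotoxicity, read by MTT assay, with a stated time of 72 h; on this read-out higher numbers stand for lower toxicity in this test and lower numbers for higher toxicity in this test:

Compound 1, `Oc1ccccc1/C=N/c1sc2c(c1-c1nc3ccccc3s1)CCC2`, gives 156 ug/mL.
Compound 2, `C(=C/c1ccccc1)\C=N\c1sc2c(c1-c1nc3ccccc3s1)CCC2`, gives 215 ug/mL.
Compound 3, `Oc1ccccc1/C=N/c1sc2c(c1-c1nc3cc(Cl)ccc3s1)CCC2`, gives 210 ug/mL.

All three compounds share a core carrying a nitrogen double-bonded to a carbon, and they differ only in what hangs on that carbon or on one aromatic ring of the core. Compound 1 and compound 3 differ in the core itself: chloro in place of hydrogen on an aromatic carbon. That change produced a 1.3-fold higher number from compound 1 to compound 3 (0.13 log units; within the scatter) in this assay, a difference too small to separate from the noise of repeated testing.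

Compound 4, `Clc1ccc2sc(-c3c(/N=C/C=C/c4ccccc4)sc4c3CCC4)nc2c1`, has not yet been measured. It differs from compound 3 in one place: 2-phenylethenyl in place of 2-hydroxyphenyl on a carbon with a double bond to nitrogen. The same change, at the same place, has already been made once among the measured compounds, from compound 1 to compound 2: 2-phenylethenyl in place of 2-hydroxyphenyl on a carbon with a double bond to nitrogen. There it gave a 1.4-fold higher number from compound 1 to compound 2 (0.14 log units; within the scatter), again a difference inside the usual scatter of this measurement.

Among the measured compounds shown here, with only one prior example, and that one within the scatter, the expectation for compound 4 can rest only on that single instance and on the value of compound 3. The step from compound 3 to compound 4 is expected to be a 1.3-fold higher number from compound 3 to compound 4 (0.11 log units; within the scatter), standing beside the earlier 1.4-fold higher number from compound 1 to compound 2 (0.14 log units; within the scatter). Compound 4 is therefore estimated to give 270 ug/mL in this assay, with a likely range of 150 ug/mL to 480 ug/mL.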

Compound 4, half-maximal cytotoxic concentration: 14.9 ug/mL
Beside the measured number, compound 4's estimate is 18-fold (1.26 log units) above it; measured number outside the range, below it.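

In this assay, a lower number means higher toxicity in this test, and putting 2-phenylethenyl in place of 2-hydroxyphenyl on the carbon with a double bond to nitrogen gave a 14-fold lower number from compound 3 to compound 4 (1.15 log units; beyond the scatter), so the change did not carry over from the core of compound 1 to the chlorinated core of compound 3: the same change on two cores in this assay, a 1.4-fold higher number (0.14 log units; within the scatter) from compound 1 to compound 2 and a 14-fold lower number (1.15 log units; beyond the scatter) from compound 3 to compound 4, 19-fold (1.29 log units) apart, beyond the scatter of two such steps

Read the other way, chloro in place of hydrogen on an aromatic carbon gave a 14-fold lower number from compound 2 to compound 4 (1.16 log units; beyond the scatter), which also differs from the same change made earlier: the same change on two cores in this assay, a 1.3-fold higher number (0.13 log units; within the scatter) from compound 1 to compound 3 and a 14-fold lower number (1.16 log units; beyond the scatter) from compound 2 to compound 4, 19-fold (1.29 log units) apart, beyond the scatter of two such steps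

Each change therefore behaves differently depending on the other, and only the compound holding both chloro and 2-phenylethenyl falls so far, but this rests on a single set of four compounds and does not show why the two changes combine in this way.

The compounds shown leave open whether the sharp fall belongs to chloro itself or would also appear with bromo or methyl in its place. They also leave open whether it needs 2-phenylethenyl, or would also follow from a plain phenyl or a longer chain on that carbon.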